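Adding a Second Chloro Group: Cytotoxicity of Compound 3

The source may hold more compounds than are shown below. What is called first, only, known or untested is meant among the compounds shown, and "the series" means these compounds.

Compound 1 `COc1cccc(/C=C2\CCC/C(=C\c3cccc(Cl)c3)C2=O)c1OC` was tested in an ADME assay on NHDF cells (Homo sapiens) for cytotoxicity, read by MTT assay, with a stated time of 72 h (a higher number here means a weaker inhibitor, a lower number a stronger inhibitor), where compound 1 gives 21400 nM. Compound 2 `COc1cccc(/C=C2\CCC/C(=C\c3ccc(Br)cc3)C2=O)c1OC` gives 21400 nM in this assay, and the step of no change at the digits printed from compound 1 to compound 2 (within the scatter) leaves compound 1 level with compound 2 on this read-out. Compound 3 `COc1cccc(/C=C2\CCC/C(=C\c3cccc(Cl)c3Cl)C2=O)c1OC` differs from compound 1 by chloro in place of hydrogen on an aromatic carbon, the entering group sitting ortho to a chloro group. Among the measured compounds shown here, the only measured step, no change at the digits printed from compound 1 to compound 2 (within the scatter), exchanged one halogenated phenyl for another without effect, so no step beyond the scatter is expected for compound 3 in this assay. Compound 3 is therefore expected to give 21400 nM, between 9000 nM and 50000 nM. The expected step is no change at the digits printed from compound 1 to compound 3 (within the scatter).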

Compound 3, half-maximal inhibitory concentration: > 50000 nM
Compound 3: no number, only a limit (the forecaster's own chance of this, stated with the estimate: 20%); at least 2.3-fold (0.36 log units) between middle value and limit.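

In this assay, compound 3 gives a limit and not a number: the limit of > 50000 nM in this assay, at which 1 of the 3 values shown sits. Chloro in place of hydrogen on this aromatic carbon, ortho to a chloro group, brings an at least 2.3-fold higher number from compound 1 to compound 3 (0.36 log units; beyond the scatter), and the 2,3-dichlorophenyl brings an at least 2.3-fold higher number from compound 2 to compound 3 (0.36 log units; beyond the scatter). This aryl group therefore does respond to a change in substitution, which the earlier exchange of halogenated phenyl groups did not show, with no change at the digits printed from compound 1 to compound 2 (within the scatter).

On these data alone, the actual value of compound 3 remains open. So does whether a methyl, a methoxy or an amine on the same carbon would behave as chloro does.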